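Notes on a tetrazolyl-for-triazolyl swap, compounds 1 to 4

This account rests on a few compounds, and the source may have more. Where it says the series, first, only, none or still open, it means among the compounds named here.

All numbers below come from a functional assay on C6 cells (Rattus norvegicus) for cytotoxicity, read by MTT assay, with a stated time of 24 h, tested at 100 ug/mL; a higher number here means a weaker effect of the compound at the concentration tested, a lower number a stronger effect.

compound 1 `Cc1ccc(-c2cs/c(=N/NC(=O)CSc3nnnn3-c3ccccc3)n2-c2ccccc2)cc1` gives 28.5%
compound 2 `Cc1ccc(-c2cs/c(=N/NC(=O)CSc3nncn3C)n2-c2ccccc2)cc1` gives 39.6%
compound 3 `Cn1cnnc1SCC(=O)N/N=c1/scc(-c2ccccc2)n1-c1ccccc1` gives 38.6%

Among the measured compounds shown here, the one change that moves the read-out is 1-phenyl-1H-tetrazol-5-yl in place of 4-methyl-4H-1,2,4-triazol-3-yl on a sulfur. Its step is a number 11.1 percentage points lower from compound 2 to compound 1 (beyond the scatter). The other change, (hydrogen in place of methyl on an aromatic carbon), is a number 1 percentage points lower from compound 2 to compound 3 (within the scatter), so compound 2 and compound 3 are not told apart in this assay; compound 1 stands lowest of the three, and its gap to compound 3 is beyond the scatter.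

Compound 4 `O=C(CSc1nnnn1-c1ccccc1)N/N=c1/scc(-c2ccccc2)n1-c1ccccc1` is not yet measured. For the measured compounds named here, it differs from compound 3 by 1-phenyl-1H-tetrazol-5-yl in place of 4-methyl-4H-1,2,4-triazol-3-yl on a sulfur, the same change, at a place described in the same words, as the one from compound 2 to compound 1. The two cores differ only by hydrogen in place of methyl on an aromatic carbon.

Going by the values given here, for compound 4 the expected step is a number 11.1 percentage points lower from compound 3 to compound 4 (beyond the scatter), set beside a number 11.1 percentage points lower from compound 2 to compound 1 (beyond the scatter), because that step is the only measured instance of this change and the core change a number 1 percentage points lower from compound 2 to compound 3 (within the scatter) did nothing. The estimate for compound 4 is 27.5%, expected between 17% and 38%.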

Compound 4, a percentage reported as activity, at one concentration (the size of the read-out at that concentration, not a potency): 35.8%
Beside the measured number, compound 4's estimate is 8.3 percentage points below it; low and high end bracket the measured number.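

Carried to the core without the methyl, the change to 1-phenyl-1H-tetrazol-5-yl in place of 4-methyl-4H-1,2,4-triazol-3-yl on a sulfur reads in this assay as a number 2.8 percentage points lower from compound 3 to compound 4 (within the scatter), and its two instances cannot be told apart: the same change on two cores in this assay, a number 11.1 percentage points lower (beyond the scatter) from compound 2 to compound 1 and a number 2.8 percentage points lower (within the scatter) from compound 3 to compound 4, 8.3 percentage points apart, within the scatter of two such steps. The core change, hydrogen in place of methyl on an aromatic carbon, now reads as a number 7.3 percentage points higher from compound 1 to compound 4 (within the scatter), and its two instances likewise cannot be told apart: the same change on two cores in this assay, a number 1 percentage points lower (within the scatter) from compound 2 to compound 3 and a number 7.3 percentage points higher (within the scatter) from compound 1 to compound 4, 8.3 percentage points apart, within the scatter of two such steps. Among the compounds shown here, this shows no measurable dependence of the change on the core, but it does not show that the change carries over, as only one of its two steps lies beyond the scatter and two cores are a thin basis.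

The compounds shown leave open which part of the entering group matters, the tetrazolyl part or its phenyl, and a 1-methyl-1H-tetrazol-5-yl on the same sulfur would separate the two. Also open, from the compounds shown here alone, is how the change behaves with a chlorine or a methoxy group in place of that methyl on the aromatic carbon.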